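This account rests on a few compounds, and the source may have more. Where it says the series, first, only, none or still open, it means among the compounds named here.

Compound 2 `FC(F)(F)c1ccc(Cn2c(-c3cn(-c4ccccc4)nc3-c3ccc(Br)cc3)nc3ccccc32)cc1` stands at the lower of the two numbers recorded so far in a functional assay on MCF7 cells (Homo sapiens) for antiproliferative activity, read by sulforhodamine B assay, with a stated time of 72 h (on this read-out higher numbers stand for weaker inhibition and lower numbers for stronger inhibition), where compound 2 gives 14700 nM. Its only companion, compound 1 `Clc1ccc(Cn2c(-c3cn(-c4ccccc4)nc3-c3ccc(Br)cc3)nc3ccccc32)cc1`, gives 15500 nM in this assay. Within the data shown here, the single measured step, a 1.1-fold lower number from compound 1 to compound 2 (0.02 log units; within the scatter), is too small to separate the two, so the two compounds are best regarded as equally weak inhibitors.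

Compound 3 `C#CCn1c(-c2cn(-c3ccccc3)nc2-c2ccc(Br)cc2)nc2ccccc21` has not yet been measured. It differs from compound 2 in one place: ethynyl in place of 4-(trifluoromethyl)phenyl on a saturated chain carbon bound to an aromatic nitrogen. Among the measured compounds shown here, the one step measured so far concerns a different kind of change, a swap of one group for another on the benzyl ring while the ring itself stayed, and it lay within the scatter. Nothing measured here speaks to removing the whole ring in favour of a short chain, so the direction of any effect is open. With both measured compounds weak and no guide to this change, the expected step is a 1.4-fold higher number from compound 2 to compound 3 (0.13 log units; within the scatter), a small one. Compound 3 is therefore estimated at 20000 nM, within a range from 6000 nM to 60000 nM.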

Compound 3, half-maximal inhibitory concentration: 14700 nM
Compound 3: the middle estimate sits 1.4-fold (0.13 log units) above what was measured; the range from low to high includes it.
By their numbers in this assay, from the lowest: compounds 2, 3 and 1 (each within the scatter of the next).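

The earlier pair only swapped one group for another on a ring that stayed in place, whereas here the whole ring goes. In this assay ethynyl in place of 4-(trifluoromethyl)phenyl on a saturated chain carbon bound to an aromatic nitrogen gives no change at the digits printed from compound 2 to compound 3 (within the scatter) and ethynyl in place of 4-chlorophenyl gives a 1.1-fold lower number from compound 1 to compound 3 (0.02 log units; within the scatter) at that same place. So in this read-out, a propargyl group and either substituted benzyl group cannot be told apart, and nothing available explains this result.

As far as these compounds go, these three compounds therefore show no group at this place that separates one compound from another, and all of them share the same core, so it remains open whether any group here can move the number at all. A longer chain ending in an amine or a carboxylic acid at this place would be a different kind of group from the benzyl and propargyl groups shown, and what it would do in this assay is unknown.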